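Trifluoromethyl in place of bromo: expected cytotoxicity of compound 3

This account rests on a few compounds, and the source may have more. Where it says the series, first, only, none or still open, it means among the compounds named here.

Compound 1 `N#Cc1c(-c2ccccc2[N+](=O)[O-])c(C#N)c(=O)n(/N=C/c2cn(-c3ccccc3)nc2-c2ccccc2)c1N`: > 200 ug/mL (a limit)
Compound 2 `N#Cc1c(-c2ccc(Br)cc2)c(C#N)c(=O)n(/N=C/c2cn(-c3ccccc3)nc2-c2ccccc2)c1N`: > 200 ug/mL (a limit)

In an ADME assay on NIH3T3 cells (Mus musculus) for cytotoxicity, read by MTT assay (a lower number here means a stronger inhibitor, a higher number a weaker inhibitor), compound 1 reaches only the limit of the assay, > 200 ug/mL. Compound 2 likewise reaches only the limit, > 200 ug/mL. The step that the two limits leave unreadable from compound 1 to compound 2 is therefore unreadable, both values sitting at the limit of > 200 ug/mL in this assay, at which 2 of the 2 values shown sit. Compound 3 `N#Cc1c(-c2ccc(C(F)(F)F)cc2)c(C#N)c(=O)n(/N=C/c2cn(-c3ccccc3)nc2-c2ccccc2)c1N` differs from compound 2 by trifluoromethyl in place of bromo on an aromatic carbon. Among the measured compounds shown here, no measured step in this assay has a readable size that bears on this change, so compound 3 is expected to sit again at the limit, the expected step being a number no higher from compound 2 to compound 3 (the limit leaves the size open). Compound 3 is accordingly estimated at 200 ug/mL, between 100 ug/mL and 400 ug/mL.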

Compound 3, half-maximal inhibitory concentration: > 200 ug/mL
Compound 3 ended at the assay's limit; the forecaster's own chance of this, stated with the estimate: 85%; the middle value lies on the limit itself.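

Compound 3 gives > 200 ug/mL as a limit of the assay, so no step among compound 1, compound 2 and compound 3 can be read: the limit of > 200 ug/mL in this assay, at which 3 of the 3 values shown sit.

The compounds shown leave open what cytotoxicity any of them has beyond that limit, and whether any change on the shared core would bring a value within the assay's range.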